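The source may report more compounds than this note shows. Statements on the series, on what has been measured and on what is new or still open speak of the compounds shown alone.

Measured so far:
- compound 1 `COc1ccc(-n2c(SCc3ccc(C)cc3)nnc2-c2cc(OC)c(OC)c(OC)c2)cc1`: > 60000 nM
- compound 2 `COc1ccc(C(=O)CSc2nnc(-c3cc(OC)c(OC)c(OC)c3)n2-c2ccc(OC)cc2)cc1`: > 60000 nM
- compound 3 `COc1ccc(-n2c(SCC(=O)c3ccc4ccccc4c3)nnc2-c2cc(OC)c(OC)c(OC)c2)cc1`: 53400 nM

Working notes on the series. In a functional assay on HT-29 cells (Homo sapiens) for inhibition, read by MTT assay, with a stated time of 48 h (on this read-out higher numbers stand for weaker inhibition and lower numbers for stronger inhibition), compound 1 gives > 60000 nM, which is a limit of the assay and not a number. Compound 2 also sits at a limit of the assay in this assay, with > 60000 nM. Among the compounds with values here, compound 3 is the only member with a measured number in this assay, 53400 nM. Two of the three values shown thus rest at the limit of > 60000 nM in this assay, at which 2 of the 3 values shown sit, and compound 1 stands there, not placed on a scale.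

Compound 4 `COc1ccc(NC(=O)CSc2nnc(-c3cc(OC)c(OC)c(OC)c3)n2-c2ccc(OC)cc2)cc1` is not yet measured. It differs from compound 1 by (4-methoxyphenyl)carbamoyl in place of 4-methylphenyl on a saturated chain carbon bound to a sulfur.

Within the data shown here, two measured steps bear on it, both replacing the same 4-methylphenyl on the saturated chain carbon bound to a sulfur with a carbonyl-bearing group. The step that the two limits leave unreadable from compound 1 to compound 2 is unreadable because both ends are limits. The step of an at least 1.1-fold lower number from compound 1 to compound 3 (0.05 log units; that floor lies within the scatter) stays within the scatter. The step of an at least 1.1-fold lower number from compound 2 to compound 3 (0.05 log units; that floor lies within the scatter) is likewise within the scatter. Across these changes the series does not leave the weak end of this assay.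

For compound 4 no step beyond the scatter is therefore expected, and the expected step is a step that the limit leaves unreadable from compound 1 to compound 4. The estimate for compound 4 in this assay is 70000 nM, in a range from 40000 nM to 150000 nM, with a likely outcome being that only a limit is again reported.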

Compound 4, half-maximal inhibitory concentration: 45300 nM
For compound 4 the middle estimate is 1.5-fold (0.19 log units) above the measured one; measured number inside the range.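

In this assay, the saturated chain carbon bound to a sulfur now gives its first step between two measured numbers, a 1.2-fold lower number from compound 3 to compound 4 (0.07 log units; within the scatter), so (4-methoxyphenyl)amino and naphthalen-2-yl on the carbonyl carbon cannot be told apart here. The other two steps, an at least 1.3-fold lower number from compound 1 to compound 4 (0.12 log units; that floor lies within the scatter) and an at least 1.3-fold lower number from compound 2 to compound 4 (0.12 log units; that floor lies within the scatter), have floors within the scatter, so the (4-methoxyphenyl)carbamoyl group, with its hydrogen-bond donor, shows no change beyond the scatter from either 4-methylphenyl or the (4-methoxyphenyl)carbonyl group. Compound 1 and compound 2 remain limits of the assay and not numbers, and the step between them cannot be read: the limit of > 60000 nM in this assay, at which 2 of the 4 values shown sit.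

The compounds shown leave open whether any group at this position can move the number beyond the scatter, as every member carries an aromatic ring at the end of this chain. A carboxylic acid, a morpholine amide or a longer chain between the sulfur and the carbonyl would test whether this flat picture holds once that ring is removed or moved further out.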